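This account rests on a few compounds, and the source may have more. Where it says the series, first, only, none or still open, it means among the compounds named here.

Compound 1 `COc1cccc([C@@H](CO)O[C@H]2CCCN(Cc3ccc(C(=O)O)cc3C)[C@H]2c2ccccc2)c1` was tested in an assay on isolated protein for activation of cGMP-dependent protein kinase 1 (Homo sapiens), read by ADP-Glo, with stated times of 30 min and 2 h; a lower number here means that less compound is needed, a higher number that more compound is needed for the effect. In this assay compound 1 gives > 200000 nM, which is a limit of the assay and not a measured number. Compound 2 `O=C(O)C12CC(CN3CCC[C@H](O[C@H](CO)c4cc(Cl)cc(Cl)c4)[C@@H]3c3ccccc3)(C1)C2` was tested in the same way. In this assay compound 2 gives > 200000 nM, again a limit rather than a number. For the measured compounds named here, both results sit at the limit of > 200000 nM in this assay, at which 2 of the 2 values shown sit, so no step between two measured numbers can be read from them, and nothing shows where within the open range either compound truly lies. Compound 3 `Cc1cc(C(=O)O)ccc1CN1CCC[C@H](O[C@H](CO)c2ccccc2)[C@@H]1c1ccccc1` shares the core of compound 1 and differs from it in one place: hydrogen in place of methoxy on an aromatic carbon. Going by the values given here, with no measured step to lean on, the step that the limit leaves unreadable from compound 1 to compound 3 is expected to be none beyond the scatter. For compound 3 the estimate in this assay is 250000 nM, within a range from 60000 nM to 1000000 nM, and a limit rather than a number is expected as the most likely outcome.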

Compound 3, half-maximal effective concentration: > 200000 nM
Compound 3 was reported as a limit; the forecaster's own chance of this, stated with the estimate: 80%; the middle value does not contradict the limit.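

In this assay, for the compounds shown here, compound 3 gives > 200000 nM, a limit and not a measured number, so no step from compound 1 can be read: the limit of > 200000 nM in this assay, at which 3 of the 3 values shown sit. The compounds shown leave open where each truly lies and whether swapping methoxy for hydrogen changes the result at all.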